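A few compounds are considered here, and "the series" means these few. Any claim that something is new, unique, unknown or untested is made for them only; others in the source may bear on it.

Measured in a functional assay on OVCAR-5 cells (Homo sapiens) for inhibition; on this read-out higher numbers stand for weaker inhibition of growth and lower numbers for stronger inhibition of growth:
- compound 1 `Nc1ccc(-c2nc3cc(F)ccc3s2)cc1I`: 280 nM
- compound 2 `Nc1ccc(-c2nc3ccccc3s2)cc1C(F)(F)F`: 17400 nM

Of these two, compound 2 has the higher number, so it shows the weaker inhibition of growth. Compound 3 `Nc1ccc(-c2nc3ccccc3s2)cc1F` is not yet measured. It has fluoro in place of trifluoromethyl on an aromatic carbon, relative to compound 2: fluoro in place of trifluoromethyl on an aromatic carbon. For the measured compounds named here, no measured pair shows this change, so the expectation is uncertain. Going by the values given here, the only guide is compound 1 at 280 nM, which shows that much lower numbers occur in this small set. A drop well beyond the scatter is expected in this assay. The expected step is a 35-fold lower number from compound 2 to compound 3 (1.54 log units; beyond the scatter). For compound 3 the estimate is 500 nM, with an expected range of 30 nM to 5000 nM.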

Compound 3, concentration for 50% growth inhibition: < 10 nM
Compound 3: a limit, no number; the forecaster's own chance of this, stated with the estimate: 8%; at least 50-fold (1.69 log units) between middle value and limit.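

For the compounds shown here, at this position, ortho to an amino group, replacing trifluoromethyl with fluoro gives an at least 1700-fold lower number from compound 2 to compound 3 (3.24 log units; beyond the scatter) in this assay, the only one-place comparison. Compound 1 differs from compound 3 in more than one place, so it gave no reading of this change. The value of compound 3 is a limit and not a number: the limit of < 10 nM in this assay, at which 1 of the 3 values shown sits.

Going by these compounds, whether a methyl, a methoxy or a nitrile at this position falls nearer compound 2 or compound 3 remains open. Also open, on these data alone, is whether the same change holds on the core of compound 1.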